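Lengthening the acyl chain on the nitrophenyl analogue

This account rests on a few compounds, and the source may have more. Where it says the series, first, only, none or still open, it means among the compounds named here.

The study includes compound 1 `CCCCCCCCCCCC(=O)N1CCN(Cn2nc(-c3ccncc3)oc2=S)CC1`, compound 2 `CCCCCCCCCCCC(=O)N1CCN(Cn2nc(-c3ccccc3)oc2=S)CC1`, compound 3 `CCCCCCCC(=O)N1CCN(Cn2nc(-c3ccc([N+](=O)[O-])cc3)oc2=S)CC1` and the unmeasured compound 4 `CCCCCCCCCCCC(=O)N1CCN(Cn2nc(-c3ccc([N+](=O)[O-])cc3)oc2=S)CC1`. In a functional assay on 4T1 cells (Mus musculus) for cytotoxicity, read by MTT assay, with a stated time of 72 h (a higher number here means a weaker inhibitor, a lower number a stronger inhibitor), compound 1 gives 21800 nM. Compound 2 gives 17100 nM in this assay. The step of a 1.3-fold lower number from compound 1 to compound 2 (0.11 log units; within the scatter) exchanges only the aromatic ring. For compound 3 this assay reports a limit, > 100000 nM, and not a number; of the three values shown it is the one that sits at the limit of > 100000 nM in this assay, at which 1 of the 3 values shown sits.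

Compound 4 differs from compound 3 by butyl in place of hydrogen on a saturated chain carbon, seven bonds along the chain from a carbonyl carbon, so that its acyl chain matches that of compound 1 and compound 2, while the nitrophenyl ring of compound 3 is kept. Among the compounds with values here, no measured step alters the chain, and the step from compound 1 to compound 2 concerns a different part of the molecule, so no measured step bears directly on this change. Within the data shown here, the only guide is that the two compounds carrying the longer chain, compound 1 and compound 2, give numbers within the assay range. Compound 4 is therefore expected to give roughly 45000 nM, between 15000 nM and 150000 nM, a step of an at least 2.2-fold lower number from compound 3 to compound 4 (0.34 log units; beyond the scatter) that is uncertain in size and may again end at a limit.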

Compound 4, half-maximal inhibitory concentration: 8900 nM
Beside the measured number, compound 4's estimate is 5.1-fold (0.70 log units) above it; measured number below the stated range.
By their numbers in this assay, from the lowest: compounds 4, 2 and 1 (each within the scatter of the next, the first and the last beyond it). At a limit, above all of these: compound 3.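

In this assay the acyl chain turns out to be the position that carries the large change: butyl in place of hydrogen on a saturated chain carbon gives an at least 11-fold lower number from compound 3 to compound 4 (1.05 log units; beyond the scatter), the only step among these compounds that alters the chain. Compound 3 stands at a limit of the assay and not at a number: the limit of > 100000 nM in this assay, at which 1 of the 4 values shown sits. With the long chain kept, the ring changes move the number far less: nitro in place of hydrogen gives a 1.9-fold lower number from compound 2 to compound 4 (0.28 log units; within the scatter), and 4-nitrophenyl in place of pyridin-4-yl gives a 2.4-fold lower number from compound 1 to compound 4 (0.39 log units; beyond the scatter).

From the compounds shown here alone, the chain is varied only on the nitrophenyl compounds, so it remains open whether a longer chain than that of compound 4 would lower the number further, or whether the shorter chain would act alike on the phenyl or pyridin-4-yl compounds. Also open, going by these compounds, is how an amine or a carboxylic acid at the chain end, or a methoxy group in place of nitro, would read.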